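A Carbamoylmethyl Cap in Place of a Methoxyphenyl Group

The source may report more compounds than this note shows. Statements on the series, on what has been measured and on what is new or still open speak of the compounds shown alone.

Compound 1, `CCOC(=O)C1=Cc2ccccc2OC1(OCc1cn(-c2cccc(OC)c2)nn1)C(F)(F)F`: > 150000 nM
Compound 2, `CCOC(=O)C1=Cc2ccccc2OC1(OCc1cc(-c2ccc(Cl)cc2)no1)C(F)(F)F`: 18200 nM

Of the compounds shown here, two built on a shared core have been tested in a functional assay on DU-145 cells (Homo sapiens) for inhibition, read by MTT assay, with a stated time of 24 h; a lower number here means a stronger inhibitor, a higher number a weaker inhibitor. For compound 1 the result is only a limit of the assay, > 150000 nM, so its true potency is not known. Compound 2 gives a proper number, 18200 nM, which is a weak inhibition. Compound 1 thus stands at the limit of > 150000 nM in this assay, at which 1 of the 2 values shown sits, the weakest outcome the assay can report. The untested compound 3, `CCOC(=O)C1=Cc2ccccc2OC1(OCc1cn(CC(=O)Nc2ccccc2F)nn1)C(F)(F)F`, differs from compound 1 by ((2-fluorophenyl)carbamoyl)methyl in place of 3-methoxyphenyl on an aromatic nitrogen. For the measured compounds named here, no measured pair shows what such a change does to the inhibition, so any expectation rests on the two values alone. Compound 3 is expected near 60000 nM, with a range from 15000 nM to 200000 nM. The expected step of an at least 2.5-fold lower number from compound 1 to compound 3 (0.39 log units; beyond the scatter) points toward stronger inhibition, though a reading that again ends at the limit is nearly as likely as a number in the region where compound 2 lies.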

Compound 3, half-maximal inhibitory concentration: 33900 nM
Beside the measured number, compound 3's estimate is 1.8-fold (0.25 log units) above it; low and high end bracket the measured number.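

The group on the aromatic nitrogen is therefore not a dead end: ((2-fluorophenyl)carbamoyl)methyl in place of 3-methoxyphenyl gives an at least 4.4-fold lower number from compound 1 to compound 3 (0.64 log units; beyond the scatter). The entering group brings a hydrogen-bond donor, the amide hydrogen, which the leaving group lacks, but the step alone cannot tie the gain to that hydrogen or to any other part of the group. On these data alone, the true size of the step remains unknown, and the value for compound 1 is only a limit: the limit of > 150000 nM in this assay, at which 1 of the 3 values shown sits.

As far as these compounds go, the carbonyl, the amide hydrogen, the fluorine and the added length all enter together, so the contribution of each stays open. Placing a plain phenylcarbamoylmethyl group without the fluorine, a benzyl group or a carboxylic acid on the same nitrogen would begin to separate these contributions.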